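The source may hold more compounds than are shown below. What is called first, only, known or untested is meant among the compounds shown, and "the series" means these compounds.

Measured compounds:

Compound 1, `COc1ccccc1N1CCN(CC(=O)NNc2nncc3ccccc23)CC1`, 550000 nM in a functional assay on thoracic aorta (Rattus norvegicus, strain Wister); on this read-out higher numbers stand for weaker inhibition and lower numbers for stronger inhibition.
Compound 2, `CN1CCN(CC(=O)NNc2nncc3ccccc23)CC1`, 160000 nM in this assay.
Compound 3, `COc1ccccc1N1CCN(CCC(=O)NNc2nncc3ccccc23)CC1`, 100000 nM in this assay.

These three compounds share a hydrazide linked to a bicyclic aromatic core, with a piperazine ring at the other end. Compound 1 and compound 2 differ in one place: methyl in place of 2-methoxyphenyl on an amine nitrogen in a ring. This change gave a 3.4-fold lower number from compound 1 to compound 2 (0.54 log units; beyond the scatter) in this assay. Compound 3 carries the same 2-methoxyphenyl group as compound 1 but a longer chain between the piperazine and the hydrazide; the difference between the two cores is not broken down here. Compound 3 gives the lowest of the three numbers, though its gap to compound 2 lies within the scatter, so no order between those two can be claimed.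

Compound 4, `CN1CCN(CCC(=O)NNc2nncc3ccccc23)CC1`, has not yet been measured. It differs from compound 3 by methyl in place of 2-methoxyphenyl on an amine nitrogen in a ring. The place of the change is the same, word for word, as between compound 1 and compound 2, so this is the same change, applied on the other core. Among the compounds with values here, the step from compound 1 to compound 2 is the only guide here. If the change behaves the same way on the core of compound 3, an estimated step of a 2.9-fold lower number from compound 3 to compound 4 (0.46 log units; beyond the scatter) would follow, which rests on compound 1 and compound 2 showing a 3.4-fold lower number from compound 1 to compound 2 (0.54 log units; beyond the scatter). On that basis compound 4 is expected to give about 35000 nM in this assay, with a plausible range from 10000 nM to 120000 nM.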

Compound 4, half-maximal inhibitory concentration: 360000 nM
Compound 4: middle estimate off by 10-fold (1.01 log units), on the low side; the measured number lies above the stated range.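

In this assay, methyl in place of 2-methoxyphenyl on an amine nitrogen in a ring gave a 3.6-fold higher number from compound 3 to compound 4 (0.56 log units; beyond the scatter), so on the core of compound 3 the number moved in the opposite direction to the one it took on the core of compound 1. Set side by side, the two steps show that in this series the change does not act as a fixed increment that can be carried from one core to another; its direction depends on the core it is made on: the same change on two cores in this assay, a 3.4-fold lower number (0.54 log units; beyond the scatter) from compound 1 to compound 2 and a 3.6-fold higher number (0.56 log units; beyond the scatter) from compound 3 to compound 4, 12-fold (1.09 log units) apart, beyond the scatter of two such steps

What this does not show is the reason for the reversal, and two pairs of compounds cannot tell which core behaves as the rule and which as the exception, or what the change would do on any third core.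

The compounds shown leave open whether the reversal follows the length of the chain, which a still longer chain carrying each of the two groups would test. They also leave open whether it is tied to these two groups alone, or would also appear with an ethyl or an unsubstituted phenyl on the same amine nitrogen.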